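Working notes: amine exchange at the thiocarbonyl of compound 1

The source may report more compounds than this note shows. Statements on the series, on what has been measured and on what is new or still open speak of the compounds shown alone.

Measured so far in a functional assay on HeLa cells (Homo sapiens) for antiproliferative activity, read by MTT assay, with a stated time of 72 h; on this read-out lower numbers stand for stronger inhibition and higher numbers for weaker inhibition:
- compound 1 `CCOC(=O)c1cc(=O)c2cc(CSC(=S)N(C)c3ccccc3)ccc2o1`: 18100 nM
- compound 2 `O=c1cc(CSC(=S)N2CCCCC2)oc2ccccc12`: > 25000 nM (a limit, not a number)
- compound 3 `COc1ccc2occ(CSC(=S)N3CCCCC3)c(=O)c2c1`: 3500 nM

Compound 1 carries the higher of the two numbers in this assay; the nearest is compound 3, whose number is lower by a margin that lies beyond the usual scatter. Compound 2 sits at the limit of > 25000 nM in this assay, at which 1 of the 3 values shown sits, so it contributes only a limit and no number. Among the measured compounds shown here, no two measured compounds differ in a single place, so no measured step is available.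

Compound 4 `CCOC(=O)c1cc(=O)c2cc(CSC(=S)N3CCOCC3)ccc2o1` is not yet measured. It differs from compound 1 by morpholin-4-yl in place of methyl(phenyl)amino on a thiocarbonyl carbon. For the measured compounds named here, nothing among the measured compounds isolates this exchange on the shared core, so the expectation rests on compound 1 alone. The step from compound 1 to compound 4 is expected to be small, a 1.1-fold higher number from compound 1 to compound 4 (0.04 log units; within the scatter), with a slight lean toward a weaker number and no confident direction beyond the scatter. Compound 4 is therefore estimated at 20000 nM, with a range from 8000 nM to 50000 nM.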

Compound 4, half-maximal inhibitory concentration: > 25000 nM
Compound 4: no number, only a limit; the forecaster's own chance of this, stated with the estimate: 35%; middle value at least 1.2-fold (0.09 log units) away from the limit.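

In this assay compound 4 gives a limit, not a number: > 25000 nM. Morpholin-4-yl in place of methyl(phenyl)amino on a thiocarbonyl carbon provides the first single-place step in the series, read as an at least 1.3-fold higher number from compound 1 to compound 4 (0.14 log units; that floor lies within the scatter), so only a floor is known and the true size of the change may lie within the scatter or beyond it. A second value in the set is now a limit rather than a number: the limit of > 25000 nM in this assay, at which 2 of the 4 values shown sit.

This one pair cannot separate the loss of the six-membered aromatic ring from the entry of the ring oxygen. Going by these compounds, whether an open-chain group such as diethylamino, or a piperazine ring carrying a free amine, on the same thiocarbonyl carbon of the shared core would give a measurable number remains open.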